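The source may hold more compounds than are shown below. What is called first, only, known or untested is meant among the compounds shown, and "the series" means these compounds.

Compound 3 `C=C(Br)C(=O)Nc1cccc(-c2cn3nc(Cc4cccc(OC)c4)sc3n2)c1` gives 3100 nM in a functional assay on CCRF-CEM cells (Homo sapiens) for inhibition, read by cell counting, with a stated time of 3 days (a lower number here means a stronger inhibitor, a higher number a weaker inhibitor), the highest of the two numbers shown. Compound 1 `C=C(Br)C(=O)Nc1cccc(-c2cn3nc(-c4ccc(F)cc4)sc3n2)c1` gives 830 nM in this assay. Compound 2 `CCOc1ccc(-c2nn3cc(-c4cccc(N)c4)nc3s2)cc1` reaches only a limit in this assay, > 250000 nM, as noted in the limit of > 250000 nM in this assay, at which 1 of the 3 values shown sits. Within the data shown here, the one measured step that bears on the change is a 3.7-fold higher number from compound 1 to compound 3 (0.57 log units; beyond the scatter), where the benzyl group replaced a phenyl carried directly on the core. Compound 4 `C=C(Br)C(=O)Nc1cccc(-c2cn3nc(-c4ccc(OCC)cc4)sc3n2)c1` differs from compound 3 by 4-ethoxyphenyl in place of 3-methoxybenzyl on an aromatic carbon, returning to a phenyl held directly on the core as in compound 1. Compound 4 is therefore expected to move back toward compound 1, by a 3.1-fold lower number from compound 3 to compound 4 (0.49 log units; beyond the scatter), a step of similar size to a 3.7-fold higher number from compound 1 to compound 3 (0.57 log units; beyond the scatter) but lower. The estimate for compound 4 in this assay is 1000 nM, between 300 nM and 4000 nM.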

Compound 4, half-maximal inhibitory concentration: 1400 nM
The estimate for compound 4 lay 1.4-fold (0.15 log units) below the measured number; measured number inside the range.
By their numbers in this assay, from the lowest: compounds 1 and 4 (each within the scatter of the next); then compound 3. At a limit, above all of these: compound 2.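

In this assay, moving the same heavy atoms from 3-methoxybenzyl to 4-ethoxyphenyl on this aromatic carbon gives a 2.2-fold lower number from compound 3 to compound 4 (0.35 log units; beyond the scatter). On the directly held phenyl, ethoxy in place of fluoro gives a 1.7-fold higher number from compound 1 to compound 4 (0.23 log units; within the scatter), so this assay does not separate these two groups. The (1-bromoethenyl)carbonyl group in place of hydrogen on the nitrogen gives an at least 170-fold lower number from compound 2 to compound 4 (2.25 log units; beyond the scatter), although the value of compound 2 is only a limit: the limit of > 250000 nM in this assay, at which 1 of the 4 values shown sits.

The compounds shown leave open whether the benzyl link or the placing of the ether accounts for the step to compound 4. They also leave open how an amine or a carboxylic acid in place of ethoxy would read.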